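The source may report more compounds than this note shows. Statements on the series, on what has been measured and on what is new or still open speak of the compounds shown alone.

Measured compounds:
compound 1 `COc1ccc(CCOC(=O)N(c2ccccc2)C2CN3CCC2CC3)cc1`, 230 nM
compound 2 `COc1ccc(CCCOC(=O)N(c2ccccc2)C2CN3CCC2CC3)cc1`, 640 nM
compound 3 `COc1ccc(CCCOC(=O)N(c2ccccc2)C2CN3CCC2CC3)cc1F`, 260 nM

In an assay on CHO cells for displacement of a labelled ligand from muscarinic acetylcholine receptor M5 (Homo sapiens), read by scintillation counting, with a stated time of 2 h (a higher number here means a weaker inhibitor, a lower number a stronger inhibitor), compound 1 gives the lowest of the three numbers; compound 3 sits within the scatter of it, and compound 2 lies furthest away. The unmeasured compound 4 `COc1ccc(COC(=O)N(c2ccccc2)C2CN3CCC2CC3)cc1F` differs from compound 1 by 3-fluoro-4-methoxyphenyl in place of 4-methoxybenzyl on a saturated chain carbon bound to an oxygen next to a carbonyl group.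

Going by the values given here, two measured steps bear on this change. Among the compounds with values here, putting 4-methoxybenzyl in place of 4-methoxyphenyl, two bonds along the chain from an oxygen next to a carbonyl group, gave a 2.8-fold higher number from compound 1 to compound 2 (0.44 log units; beyond the scatter), so the longer chain read weaker; compound 4 goes the other way, to a shorter chain than compound 1, but no measured pair shows that direction. Putting fluoro in place of hydrogen on an aromatic carbon gave a 2.5-fold lower number from compound 2 to compound 3 (0.39 log units; beyond the scatter), a modest gain, while a 1.1-fold higher number from compound 1 to compound 3 (0.05 log units; within the scatter) shows the two changes nearly cancelling.

Compound 4 combines the shorter chain with the fluoro, so a modest lower number is expected, a 1.6-fold lower number from compound 1 to compound 4 (0.22 log units; within the scatter). Compound 4 is therefore estimated at 140 nM, with a range from 50 nM to 450 nM.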

Compound 4, inhibition constant: 40 nM
For compound 4 the middle estimate is 3.5-fold (0.54 log units) above the measured one; measured number below the stated range.
By their numbers in this assay, from the lowest: compound 4; then compounds 1 and 3 (each within the scatter of the next); then compound 2.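

In this assay, moving from the 4-methoxybenzyl to the 3-fluoro-4-methoxyphenyl on a saturated chain carbon bound to an oxygen next to a carbonyl group gave a 5.8-fold lower number from compound 1 to compound 4 (0.76 log units; beyond the scatter), the first step from compound 1 to a lower number beyond the scatter. The earlier steps shown here from compound 1 had led only to a higher number or to one within the scatter, so this place in the molecule can carry a change that improves on compound 1. Nothing measured here accounts for the size of this step.

From the compounds shown here alone, the step carries the shorter chain and the fluoro together, so the share of each remains unknown. Going by these compounds, how a chloro in place of the fluoro, or a hydroxyl in place of the methoxy, would read on this shorter chain also stays open.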